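The compounds below may be only part of what the source reports. "The series", "measured", "known", "first", "only" and "open" are said of these compounds alone.

Three compounds sharing one core were measured in an assay on CHO cells for displacement of a labelled ligand from adenosine receptor A3 (Homo sapiens), read by scintillation counting, with a stated time of 120 min, tested at 10 uM; on this read-out lower numbers stand for less inhibition and higher numbers for more inhibition at the one concentration tested (going by the name of the read-out). Compound 1 `Nc1scc(CN2CCN(c3ccc(OC(F)(F)F)cc3)CC2)c1C(=O)c1ccc(Cl)cc1` gives 1%, compound 2 `Nc1scc(CN2CCN(C3CCCC3)CC2)c1C(=O)c1ccc(Cl)cc1` gives 3%, and compound 3 `Nc1scc(CN2CCN(c3ccc(F)c(F)c3)CC2)c1C(=O)c1ccc(Cl)cc1` gives 1%. Compound 3 stands level with compound 1 at the digits shown, the two together being the lowest of the three numbers, while a number 2 percentage points lower from compound 2 to compound 3 (within the scatter), so all three lie within the scatter of one another. Compound 4 `Nc1scc(CN2CCN(c3cc(Cl)ccc3Cl)CC2)c1C(=O)c1ccc(Cl)cc1` differs from compound 3 in one place: 2,5-dichlorophenyl in place of 3,4-difluorophenyl on an amine nitrogen in a ring. For the measured compounds named here, the steps that bear on this are earlier exchanges of the group on the same ring nitrogen: no change at the digits printed from compound 1 to compound 3 (within the scatter) and a number 2 percentage points higher from compound 1 to compound 2 (within the scatter). Neither moved the number beyond the scatter, and the same is expected here, with a number 1 percentage points higher from compound 3 to compound 4 (within the scatter). Compound 4 is therefore estimated at 2%, between -6% and 10%.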

Compound 4, a percentage reported as inhibition, at one concentration (the size of the read-out at that concentration, not a potency): 1%
Compound 4: middle estimate off by 1 percentage points, on the high side, and the stated range covers the measured number.
By their numbers in this assay, from the lowest: compounds 1, 3, 4 and 2 (each within the scatter of the next).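

In this assay, a phenyl carrying two chlorines on the ring nitrogen behaves like the fluorinated phenyls, with no change at the digits printed from compound 3 to compound 4 (within the scatter), no change at the digits printed from compound 1 to compound 4 (within the scatter) and a number 2 percentage points lower from compound 2 to compound 4 (within the scatter). This position has now taken 2,5-dichlorophenyl as well as the three earlier groups without any step leaving the scatter. No measurement offered here accounts for this.

Going by these compounds, whether a quite different group on this nitrogen, such as a chain ending in a carboxylic acid, would move the number remains open. So does the effect of any change elsewhere on the shared core.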